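This account rests on a few compounds, and the source may have more. Where it says the series, first, only, none or still open, it means among the compounds named here.

Three compounds of the series have numbers in a functional assay on A549 cells (Homo sapiens) for antiproliferative activity, read by MTT assay, with a stated time of 72 h; a lower number here means a stronger inhibitor, a higher number a weaker inhibitor. Compound 2 `C/C=C/C(=O)Nc1cc2c(N3CCCc4ccccc43)ncnc2cc1OC` gives 8190 nM, the lowest number of the three shown. Among the compounds with values here, compound 3 `C/C=C/C(=O)Nc1cc2c(N3CCCc4ccccc43)ncnc2cc1O[C@@H]1CCOC1` gives 10800 nM; the step of a 1.3-fold higher number from compound 2 to compound 3 (0.12 log units; within the scatter) is the only single-point change measured so far. Compound 1 `C=C(C)C(=O)Nc1cc2c(N3CCc4ccccc43)ncnc2cc1O[C@@H]1CCOC1` gives 16600 nM, the furthest from compound 2 and beyond the scatter, but compound 1 differs from compound 2 in more than one place, so only the two values themselves can be set side by side.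

Compound 4 `COc1cc2ncnc(N3CCCc4ccccc43)c2cc1NC(=O)/C=C/CN1CCCC1` is compound 2 with pyrrolidin-1-yl in place of hydrogen on a saturated chain carbon bound to a double-bonded chain carbon. Within the data shown here, no measured step touches this part of the molecule: the step from compound 2 to compound 3 concerns the group on the aromatic oxygen, not the chain of the amide. Expectation for this assay therefore rests on no precedent within the series, and the expected step of a 1.6-fold lower number from compound 2 to compound 4 (0.21 log units; within the scatter) is kept modest, toward a somewhat lower number, with a wide range around it. Compound 4 is expected to give 5000 nM, between 1500 nM and 16000 nM.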

Compound 4, half-maximal inhibitory concentration: 2230 nM
Estimate against measurement, compound 4: 2.2-fold (0.35 log units) above, and the stated range covers the measured number.
By their numbers in this assay, from the lowest: compound 4; then compounds 2, 3 and 1 (each within the scatter of the next, the first and the last beyond it).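

In this assay, within the data shown here, pyrrolidin-1-yl in place of hydrogen on a saturated chain carbon bound to a double-bonded chain carbon gives a 3.7-fold lower number from compound 2 to compound 4 (0.56 log units; beyond the scatter), the first single-point step that lies beyond the scatter. This end of the amide chain is therefore a position where a change moves the number, whereas the change on the aromatic oxygen, a 1.3-fold higher number from compound 2 to compound 3 (0.12 log units; within the scatter), stays within the scatter. No measured evidence accompanies this step to account for it.

Going by these compounds, it remains open whether the lower number is particular to pyrrolidin-1-yl or also holds for a dimethylamino group, piperidin-1-yl or morpholin-4-yl on the same carbon, or for a longer chain carrying the amine. On these data alone, it also remains open whether pyrrolidin-1-yl gives a similar step when placed on compound 3, with oxolan-3-yl on the aromatic oxygen.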